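The compounds below may be only part of what the source reports. "The series", "measured", "known", "first", "only" and "open" are said of these compounds alone.

Working notes on the series.

Three compounds share one core. In a physicochemical assay for lipophilicity (on this read-out lower numbers stand for lower lipophilicity and higher numbers for higher lipophilicity), compound 1 `CC(=N)Nc1cccc(C(=O)NNC(=O)CC(CC(=O)O)c2ccc(Cl)cc2)c1` gives 2. In this assay compound 2 `CC(=N)Nc1cccc(C(=O)NNC(=O)CC(CC(=O)O)c2ccc(Br)cc2)c1` gives 2.27, and compound 3 `CC(=N)Nc1cccc(C(=O)NNC(=O)CC(CC(=O)O)c2ccc(-c3ccccc3)cc2)c1` gives 3.11 in this assay. Compound 3 stands highest of the three numbers: the steps of a number 0.84 log units higher from compound 2 to compound 3 (beyond the scatter) and a number 1.11 log units higher from compound 1 to compound 3 (beyond the scatter) both lie beyond the scatter, whereas a number 0.27 log units higher from compound 1 to compound 2 (within the scatter) stays within it.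

Compound 4 `O=C(O)CC(CC(=O)NNC(=O)CCCCNc1ccccn1)c1ccc(-c2ccccc2)cc1` is the next member. It differs from compound 3 by a group of 11 heavy atoms (9 carbon, 2 nitrogen; one six-membered aromatic ring with 1 hetero atom) in place of a group of 10 heavy atoms (8 carbon, 2 nitrogen; one six-membered aromatic ring of carbon only), on a carbonyl carbon. Among the measured compounds shown here, all three measured steps concern the substituent on the aromatic carbon at the far end of the core, not the carbonyl carbon where compound 4 changes; no measured step addresses that position, so the existing steps inform only the scale on which this read-out has moved, the largest being a number 1.11 log units higher from compound 1 to compound 3 (beyond the scatter). The change in compound 4 is larger in scope than any measured step, as it exchanges the whole group on the carbonyl carbon rather than one ring substituent, and its direction in this assay is uncertain.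

The expected step for compound 4 is a number 0.59 log units higher from compound 3 to compound 4 (beyond the scatter), an upward move carried with a wide band. Compound 4 is estimated at 3.7 in this assay, within the expected range 2.8 to 4.6.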

Compound 4, partition coefficient: 3.74
Estimate against measurement, compound 4: 0.04 log units below; the measured number falls inside the stated range.
By their numbers in this assay, from the lowest: compounds 1 and 2 (each within the scatter of the next); then compound 3; then compound 4.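

The carbonyl carbon now has a measured step of its own: with 4-((pyridin-2-yl)amino)butyl as the entering group, the change in this assay is a number 0.63 log units higher from compound 3 to compound 4 (beyond the scatter), so the read-out in this series moves at this position as well as at the aromatic carbon. The step is smaller than a number 1.11 log units higher from compound 1 to compound 3 (beyond the scatter), the largest ring-substituent step, and it shows that exchanging the whole group on the carbonyl carbon need not produce the largest move in the series. The exchange alters the ring and the chain together, and the step belongs to the whole group rather than to one part of it. Nothing available bears on why the number moved.

Going by these compounds, how the read-out would respond to a longer chain, or to a plain amine in place of the pyridin-2-yl ring at the end of the butyl chain, stays open. Also open, on these data alone, is whether the same exchange on the carbonyl carbon would give a similar step with chloro or bromo on the aromatic carbon, as in compound 1 and compound 2.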